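The source may report more compounds than this note shows. Statements on the series, on what has been measured and on what is new or still open speak of the compounds shown alone.

Values in a functional assay on MDA-MB-231 cells (Homo sapiens) for inhibition, read by CCK-8 assay, with a stated time of 48 h; a higher number here means a weaker inhibitor of growth, a lower number a stronger inhibitor of growth:
Compound 1 `Cc1ccccc1Nc1nc(NC2CC2)ncc1Cl`: > 100000 nM, a limit and not a number.
Compound 2 `Cc1ccc(Nc2ncc(Cl)c(Nc3ccccc3C)n2)cc1`: > 100000 nM, a limit and not a number.
Compound 3 `CN1CCN(c2ccc(Nc3ncc(Cl)c(NCc4ccccc4)n3)nc2)CC1`: 24800 nM.

Among the compounds with values here, compound 3 gives 24800 nM, the only true number among the three, and so it is the single firm reference point in this assay. The other two results both sit at one ceiling: the limit of > 100000 nM in this assay, at which 2 of the 3 values shown sit.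

The next compound to be measured is compound 4 `Cc1ccc(Nc2nc(Nc3ccc(N4CCN(C)CC4)cn3)ncc2Cl)cc1`. It has the same atoms as compound 3, joined differently: 4-methylphenyl in place of benzyl on a nitrogen on an aromatic ring. Put simply, 4-methylphenyl stands in place of benzyl on a nitrogen on an aromatic ring.

Within the data shown here, only one measured step brings in 4-methylphenyl, and that is a step that the two limits leave unreadable from compound 1 to compound 2. Both of its ends are limits, so it gives neither a size nor a direction to carry over. That leaves compound 3 at 24800 nM as the only basis for an expectation. The expected step in this assay is a 1.2-fold lower number from compound 3 to compound 4 (0.09 log units; within the scatter), which means no expected change beyond the scatter in either direction, though with little evidence behind it. For compound 4 the estimated value is 20000 nM, with an expected range from 5000 nM to 80000 nM.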

Compound 4, concentration for 50% growth inhibition: 4030 nM
Compound 4: the middle estimate sits 5.0-fold (0.70 log units) above what was measured; the whole stated range lies above it.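

Swapping benzyl for 4-methylphenyl on a nitrogen on an aromatic ring gives, in this assay, a 6.2-fold lower number from compound 3 to compound 4 (0.79 log units; beyond the scatter), so the group at this place clearly matters for growth inhibition in these cells. The two groups match in every count computed for them, so the change amounts to a rearrangement of the same atoms, from benzylamino to (4-methylphenyl)amino, and even that is enough to move the result beyond the usual scatter. The only earlier step that brought in 4-methylphenyl cannot be read, since both of its ends are limits, so this is the first measurable size for that group, and it comes from a compound that stands clear of the ceiling: the limit of > 100000 nM in this assay, at which 2 of the 4 values shown sit.

This step rests on a single pair of compounds, and it does not separate the part played by the methyl group from the part played by a ring sitting directly on the nitrogen. A plain phenyl at this place would address that question, and a longer chain such as 2-phenylethyl would show whether extending the link beyond benzyl carries the trend further.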